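Swapping the Aryl Group on a Shared Lactam Core

The source may hold more compounds than are shown below. What is called first, only, known or untested is meant among the compounds shown, and "the series" means these compounds.

Two compounds on a shared core have been examined in a functional assay on DU-145 cells (Homo sapiens) for cytotoxicity, read by sulforhodamine B assay, with a stated time of 48 h; on this read-out higher numbers stand for weaker inhibition and lower numbers for stronger inhibition. Compound 1 `CO[C@@H]1CC=C2N(c3ccc([N+](=O)[O-])cc3)C(=O)C[C@]2(c2ccccc2)O1` gives 8100 nM in this assay, the highest of the two numbers. Compound 2 `COc1cc(OC)cc(N2C(=O)C[C@]3(c4ccccc4)O[C@H](OC)CC=C23)c1` gives 6100 nM in this assay, a number that lies within the scatter of the value for compound 1, so the two cannot be told apart. Compound 3 `CO[C@@H]1CC=C2N(c3c[nH]c4ccccc34)C(=O)C[C@]2(c2ccccc2)O1` has not been measured; it differs from compound 1 by 1H-indol-3-yl in place of 4-nitrophenyl on an amide-type nitrogen in a ring. For the measured compounds named here, no measured pair shows what such a change does on this core, so the expectation rests only on compounds 1 and 2, whose two aryl groups give values within the scatter of each other. Compound 3 is therefore expected to stay close to compound 1, with a step of a 1.4-fold lower number from compound 1 to compound 3 (0.13 log units; within the scatter) that need not exceed the scatter in either direction. The estimate for compound 3 in this assay is 6000 nM, within a range of 1500 nM to 25000 nM.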

Compound 3, half-maximal inhibitory concentration: 7330 nM
Beside the measured number, compound 3's estimate is 1.2-fold (0.09 log units) below it, within the range that was stated.
By their numbers in this assay, from the lowest: compounds 2, 3 and 1 (each within the scatter of the next).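

For the compounds shown here, the step gives the first direct reading of a change on the amide-type nitrogen in a ring of this core: in this assay there is a 1.1-fold lower number from compound 1 to compound 3 (0.04 log units; within the scatter) even though 1H-indol-3-yl, with one five-membered aromatic ring with 1 hetero atom, one six-membered aromatic ring of carbon only and 1 hydrogen-bond donor, replaces 4-nitrophenyl, with its single six-membered aromatic ring and 2 hydrogen-bond acceptors. At this position, then, this exchange of one aromatic group for a quite different one of the same heavy-atom total does not move the number beyond the scatter. No other kind of measurement accompanies these numbers, and nothing here accounts for the values staying together.

Going by these compounds, all three compounds carry an aromatic group on this nitrogen, so it remains open whether a plain hydrogen, a methyl group, a cyclohexyl group or an aryl group bearing an amine or a carboxylic acid would stay in the same range in this assay. On these data alone, the phenyl group and the methoxy group on the shared core are also the same throughout, and what a change at either would do remains unknown.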